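From Isopropoxy to Fluoro at the Assay Limit

A few compounds are considered here, and "the series" means these few. Any claim that something is new, unique, unknown or untested is made for them only; others in the source may bear on it.

Measured so far:
Compound 1 `COc1ccc(C2=C(c3cc(OC)c(OC)c(OC)c3)C(=O)C(OC(C)=O)C2)cc1OC(C)C`: > 100 ug/mL
Compound 2 `COc1ccc(C2=C(c3cc(OC)c(OC)c(OC)c3)C(=O)CC2O[SiH2]C(C)(C)C)cc1`: > 100 ug/mL

In an ADME assay on HT-29 cells (Homo sapiens) for cytotoxicity, read by MTT assay, with a stated time of 72 h (on this read-out lower numbers stand for stronger inhibition and higher numbers for weaker inhibition), compound 1 gives > 100 ug/mL, which is a limit of the assay and not a number. Compound 2 gives > 100 ug/mL, which is also a limit. Compound 1 therefore has no exact number of its own and stands with the limit of > 100 ug/mL in this assay, at which 2 of the 2 values shown sit.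

The next compound is compound 3 `COc1ccc(C2=C(c3cc(OC)c(OC)c(OC)c3)C(=O)C(OC(C)=O)C2)cc1F`, which keeps the core of compound 1 but carries fluoro in place of isopropoxy on an aromatic carbon. Among the compounds with values here, no pair of measured compounds shows what a single change does here, so any expectation is poorly anchored. A move towards stronger inhibition in this assay is expected, though its size is uncertain, and the expected step is an at least 1.6-fold lower number from compound 1 to compound 3 (0.22 log units; that floor lies within the scatter). Compound 3 may also return only a limit. For compound 3 the estimated value is 60 ug/mL, with an expected range from 5 ug/mL to 200 ug/mL.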

Compound 3, half-maximal inhibitory concentration: < 1 ug/mL
Compound 3 was reported as a limit; the forecaster's own chance of this, stated with the estimate: 55%; middle value at least 60-fold (1.77 log units) from the limit.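

On an aromatic carbon ortho to a methoxy group, fluoro in place of isopropoxy gives, in this assay, an at least 100-fold lower number from compound 1 to compound 3 (2.00 log units; beyond the scatter). Within the data shown here, the earlier compounds showed only one end of the measured range, and this single change on the shared core is the first to reach the other end: the limit of < 1 ug/mL in this assay, at which 1 of the 3 values shown sits. Both ends of the step are limits of the assay and not numbers, so it marks a minimum for the change and not its true size, and compound 1 remains at the upper end: the limit of > 100 ug/mL in this assay, at which 2 of the 3 values shown sit.

The compounds shown leave open how far beyond its limit compound 3 truly lies. They also leave open whether the gain belongs to fluoro itself or to the loss of isopropoxy, a question that a hydrogen, hydroxy or chloro on this same carbon would address.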